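Chloro for hydrogen on two cores: working notes

The compounds below may be only part of what the source reports. "The series", "measured", "known", "first", "only" and "open" are said of these compounds alone.

Compound 1 `COc1ccc(C2CC(c3ccccc3)=NN2C(=O)c2cc3ccccc3o2)cc1` gives 4.57 ug/mL in a functional assay on A2780 cells (Homo sapiens) for antiproliferative activity, read by MTT assay, with a stated time of 72 h; on this read-out higher numbers stand for weaker inhibition and lower numbers for stronger inhibition. Compound 2 `COc1ccc(C2CC(c3ccc(Cl)cc3)=NN2C(=O)c2cc3ccccc3o2)cc1` carries the change (chloro in place of hydrogen on an aromatic carbon); in this assay compound 2 gives 5.74 ug/mL, and the step of a 1.3-fold higher number from compound 1 to compound 2 (0.10 log units; within the scatter) stays within the scatter. Compound 3 `O=C(c1cc2ccccc2o1)N1N=C(c2ccc(F)cc2)CC1c1ccccc1` is built on a different core; the difference between the two cores is not broken down here. In this assay compound 3 gives 11.8 ug/mL, the highest of the three numbers. Compound 4 `O=C(c1cc2ccccc2o1)N1N=C(c2ccc(F)cc2)CC1c1ccc(Cl)cc1` is not yet measured. It differs from compound 3 by chloro in place of hydrogen on an aromatic carbon, the same change seen between compound 1 and compound 2, at a place described in the same words. Because a 1.3-fold higher number from compound 1 to compound 2 (0.10 log units; within the scatter) lies within the scatter, the step expected here is a 1.2-fold higher number from compound 3 to compound 4 (0.07 log units; within the scatter), likewise small. Compound 4 is expected to give about 14 ug/mL in this assay, with a likely range from 7 ug/mL to 28 ug/mL.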

Compound 4, half-maximal inhibitory concentration: > 50 ug/mL
Compound 4: a limit, no number; the forecaster's own chance of this, stated with the estimate: 5%; middle value at least 3.5-fold (0.55 log units) from the limit.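

In this assay compound 4 gives > 50 ug/mL as a limit of the assay and not a number. Chloro in place of hydrogen on an aromatic carbon brings an at least 4.2-fold higher number from compound 3 to compound 4 (0.62 log units; beyond the scatter) and so does not carry over in size from one core to the other: the same change on two cores in this assay, a 1.3-fold higher number (0.10 log units; within the scatter) from compound 1 to compound 2 and an at least 4.2-fold higher number (0.62 log units; beyond the scatter) from compound 3 to compound 4, at least 3.3-fold (0.52 log units) apart, beyond the scatter of two such steps. These two pairs show that the outcome of this change depends on the core, but they do not show the true size of the second step or which difference between the cores matters.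

From the compounds shown here alone, it remains open whether this holds for other cores. Also open, going by these compounds, is how compound 3 would respond to an amine or a carboxylic acid in place of that hydrogen.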